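Swapping a dienyl chain for a chlorophenoxy propyl chain

The source may hold more compounds than are shown below. What is called first, only, known or untested is meant among the compounds shown, and "the series" means these compounds.

Of the compounds shown here, three sharing one core have been tested in a functional assay on PANC-1 cells (Homo sapiens) for inhibition, read by MTT assay, with a stated time of 24 h, tested at 10 uM; on this read-out lower numbers stand for less inhibition and higher numbers for more inhibition at the one concentration tested (going by the name of the read-out). Compound 1 `CC(C)=CCC/C(C)=C/COc1cc(=O)n(CCCO)c2c1CC(CC=C(C)C)C(C)(C)C2` gives 18.4%, the highest of the three numbers. Compound 2 `CC(C)=CCC1Cc2c(OCCCNS(=O)(=O)c3ccc(Cl)cc3)cc(=O)n(CCCO)c2CC1(C)C` gives 9.8%, which lies within the scatter of compound 1. Compound 3 `COc1ccc(C(=O)NCCCOc2cc(=O)n(CCCO)c3c2CC(CC=C(C)C)C(C)(C)C3)cc1` gives 2.5%, the furthest from compound 1 and beyond the scatter. Within the data shown here, the only single-point step among the measured compounds is a number 7.3 percentage points lower from compound 2 to compound 3 (within the scatter), a change on an amine nitrogen that does not alter the number beyond the scatter.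

Compound 4 `CC(C)=CCC1Cc2c(OCCCOc3ccc(Cl)cc3)cc(=O)n(CCCO)c2CC1(C)C` is not yet measured. It differs from compound 1 as follows: 2-(4-chlorophenoxy)ethyl in place of 2,6-dimethylhepta-1,5-dien-1-yl on a saturated chain carbon bound to an oxygen on an aromatic ring. Among the measured compounds shown here, no measured step matches this change directly; the step from compound 2 to compound 3 concerns a different part of the side chain. What the data do show is that compound 1, carrying the 3,7-dimethylocta-2,6-dien-1-yl chain, sits highest, while compound 2, whose side chain also carries a chlorine-bearing aromatic ring, sits lower by an amount within the scatter.

On that basis compound 4 is expected to give 10%, with a likely range from 0% to 22%. The step of a number 8.4 percentage points lower from compound 1 to compound 4 (within the scatter) is expected to be downward but near the edge of the scatter, because the value of compound 2 9.8% already suggests such chains give modest readings.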

Compound 4, a percentage reported as inhibition, at one concentration (the size of the read-out at that concentration, not a potency): 0%
Estimate against measurement, compound 4: 10 percentage points above; the range from low to high includes it.
By their numbers in this assay, from the lowest: compounds 4, 3, 2 and 1 (each within the scatter of the next, the first and the last beyond it).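

In this assay the place on a saturated chain carbon bound to an oxygen on an aromatic ring now has a single change of measured size: a number 18.4 percentage points lower from compound 1 to compound 4 (beyond the scatter) when the 3-(4-chlorophenoxy)propyl chain replaces the 3,7-dimethylocta-2,6-dien-1-yl chain, and the earlier step among the compounds did not go beyond the scatter. Exchanging the group on the saturated chain carbon, three bonds along the chain from an oxygen on an aromatic ring, does not separate the compounds in the same way: a number 2.5 percentage points lower from compound 3 to compound 4 (within the scatter) and a number 9.8 percentage points lower from compound 2 to compound 4 (within the scatter) both stay within the scatter, so 4-chlorophenoxy, ((4-methoxyphenyl)carbonyl)amino and ((4-chlorophenyl)sulfonyl)amino cannot be told apart in this read-out. No available evidence accounts for the loss seen on leaving the dienyl chain.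

The compounds shown leave open whether the double bonds or the length of the 3,7-dimethylocta-2,6-dien-1-yl chain matter, which a saturated chain of the same length, such as 3,7-dimethyloctyl, would address. They also leave open whether an amine or a carboxylic acid in place of the 4-chlorophenoxy group would change the reading.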